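The source may report more compounds than this note shows. Statements on the series, on what has been measured and on what is new or still open speak of the compounds shown alone.

Series sharing the core of compound 1 `Cc1cc(O)c(C2=NN(c3ccc(S(N)(=O)=O)cc3)C(c3ccccc3Cl)C2)cc1Cl`, with compound 2 `COc1cc(C)c(Cl)cc1C1=NN(c2ccc(S(N)(=O)=O)cc2)C(c2ccccc2)C1` and compound 3 `COc1cc(C)c(Cl)cc1C1=NN(c2ccc(S(N)(=O)=O)cc2)C(c2cccc(O)c2)C1`, tested in a functional assay on the whole organism (strain Wistar) for inhibition, with Rattus norvegicus as the target, read by paw edema, with stated times of 30 min and 5 h, at a dose of 20 mg/kg by the oral route; on this read-out lower numbers stand for less inhibition and higher numbers for more inhibition at the one dose given (going by the name of the read-out). Compound 1 gives 71.4%, compound 2 gives 59.5% and compound 3 gives 16.7%, the lowest of the three, with compound 2 nearest and compound 1 furthest. Among the compounds with values here, the single measured one-place step, a number 42.8 percentage points lower from compound 2 to compound 3 (beyond the scatter), falls on the same saturated ring carbon that is changed next. Compound 4 `COc1ccc(C2CC(c3cc(Cl)c(C)cc3OC)=NN2c2ccc(S(N)(=O)=O)cc2)cc1OC` differs from compound 3 by 3,4-dimethoxyphenyl in place of 3-hydroxyphenyl on a saturated ring carbon. Within the data shown here, the hydroxy introduced in that measured step leaves, so a rise is expected, though the two methoxy groups have no measured counterpart in this set and the recovery need not reach compound 2. The step expected is a number 28.3 percentage points higher from compound 3 to compound 4 (beyond the scatter). Compound 4 is estimated at 45%, range 20% to 65%.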

Compound 4, a percentage reported as inhibition, in the whole organism at one dose (the size of the read-out at that dose, not a potency): 47.6%
Beside the measured number, compound 4's estimate is 2.6 percentage points below it, within the range that was stated.
By their numbers in this assay, from the lowest: compound 3; then compound 4; then compound 2; then compound 1.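

Placing 3,4-dimethoxyphenyl in place of 3-hydroxyphenyl on this saturated ring carbon gives a number 30.9 percentage points higher from compound 3 to compound 4 (beyond the scatter) in this assay, so a substituted aryl group here need not fall as low as compound 3. Replacing phenyl with the same group gives a number 11.9 percentage points lower from compound 2 to compound 4 (beyond the scatter), so substitution with two methoxy groups does not match plain phenyl and the step is modest.

As far as these compounds go, how 4-methoxyphenyl, 3-aminophenyl or 3-carboxyphenyl would read at this carbon remains open. Nothing available explains either step.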